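This account rests on a few compounds, and the source may have more. Where it says the series, first, only, none or still open, it means among the compounds named here.

Measured so far:
- compound 1, `COc1ccc(C2CC(=O)c3ccc(C)cc3O2)cc1`: "not active" (no number reported)
- compound 2, `Cc1ccc(-c2cc(=O)c3ccc(C)cc3o2)cc1`: 40%
- compound 3, `COc1ccc(C2CC(=O)c3ccc(OC)cc3O2)cc1`: "not active" (no number reported)

Of the compounds shown here, three have been tested in an in vitro assay on BTI-TN-5B1-4 cells for inhibition of Amine oxidase [flavin-containing] A (Homo sapiens), tested at 100 uM; on this read-out higher numbers stand for more inhibition at the one concentration tested (going by the name of the read-out) and lower numbers for less inhibition. Compound 2 gives 40% in this assay. For compound 1 this assay reports "not active" (no number reported), so no single number stands behind it; the same holds for compound 3, which is also reported as "not active" (no number reported). Compound 1 therefore cannot be placed on a scale against compound 2; all that is known is that it did not show inhibition that was worth a number, and that compound 3, which shares its core and differs only in the group on one of its rings, is in the same position.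

Compound 4, `Cc1ccc2c(c1)OC(c1ccccc1)CC2=O`, keeps the core of compound 1 and changes one place: hydrogen in place of methoxy on an aromatic carbon. The methoxy leaves from an aromatic carbon of a six-membered aromatic ring of carbon only, para to a large group, and a hydrogen takes its place. Within the data shown here, no measured pair shows this exact change, so the size of the step in this assay can only be guessed; with both compound 1 and compound 3 reported without a number, nothing suggests that the step will lift compound 4 beyond the scatter. Compound 4 is expected to give about 10%, within a range from 0% to 30%, and it may well be reported without a number again.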

Compound 4, a percentage reported as inhibition, at one concentration (the size of the read-out at that concentration, not a potency): "not active" (no number reported)
Nothing numeric was reported for compound 4, so the estimate cannot be set against anything.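

Compound 1 gives "not active" (no number reported) and compound 4 gives "not active" (no number reported) in this assay, so no step can be read between these two compounds. Nothing available bears on this result. The compounds shown leave open whether putting hydrogen in place of methoxy changes the inhibition at all.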